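Swapping the amide chain of compound 1

The source may report more compounds than this note shows. Statements on the series, on what has been measured and on what is new or still open speak of the compounds shown alone.

Compound 1 `CC(C)(CO)CNC(=O)c1cc2cc(C#N)ccc2n1Cc1cccc(OC(F)(F)F)c1` reads 136 mL.min-1.g-1 in an in vitro ADME assay on microsomes from Gut (Homo sapiens) for metabolic stability, in the presence of a further agent that is not named here; on this read-out higher numbers stand for fast clearance and lower numbers for slow clearance. That lies within the scatter of compound 2 `CCOc1ccc(OC(F)(F)F)cc1Cn1c(C(=O)NCC(C)(C)CO)cc2cc(C#N)ccc21` at 103 mL.min-1.g-1 but stands clear of compound 3 `CCCOc1cccc(Cn2c(C(=O)NCC(C)(C)CO)cc3cc(C#N)ccc32)c1` at 45 mL.min-1.g-1 on the slow side. Compound 4 `N#Cc1ccc2c(c1)cc(C(=O)NCCC(O)C(F)(F)F)n2Cc1cccc(OC(F)(F)F)c1` keeps the shared core and changes only the group on a saturated chain carbon bound to an amide-type nitrogen (3,3,3-trifluoro-2-hydroxypropyl in place of 1-(hydroxymethyl)-1-methylethyl on a saturated chain carbon bound to an amide-type nitrogen). Going by the values given here, the two measured steps (a 1.3-fold lower number from compound 1 to compound 2 (0.12 log units; within the scatter); a 3.0-fold lower number from compound 1 to compound 3 (0.48 log units; beyond the scatter)) leave that chain untouched, so they offer no direct precedent for this change. No shift beyond the scatter is therefore expected in this assay, and the estimated step is small (a 1.4-fold lower number from compound 1 to compound 4 (0.13 log units; within the scatter)). Compound 4 is estimated at 100 mL.min-1.g-1 (expected range 50 mL.min-1.g-1 to 200 mL.min-1.g-1).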

Compound 4, intrinsic clearance in microsomes: < 6 mL.min-1.g-1
Compound 4 gave a limit, no number (the forecaster's own chance of this, stated with the estimate: 2%); middle value at least 16-fold (1.22 log units) from the limit.
By their numbers in this assay, from the lowest: compound 3; then compounds 2 and 1 (each within the scatter of the next). At a limit, below all of these: compound 4.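

The amide chain turns out to be a sensitive position in this assay: 3,3,3-trifluoro-2-hydroxypropyl in place of 1-(hydroxymethyl)-1-methylethyl gives an at least 22-fold lower number from compound 1 to compound 4 (1.35 log units; beyond the scatter). Going by these compounds alone, the earlier steps left this chain untouched, so this is the first sign that a change here can produce a large step. The reading for compound 4 is a limit and not a number: the limit of < 6 mL.min-1.g-1 in this assay, at which 1 of the 4 values shown sits.

On these data alone, how far compound 4 lies past that limit stays open. So does whether the same chain without its trifluoromethyl, or with an amine in place of its hydroxy group, would give a step of this size.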